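A few compounds are considered here, and "the series" means these few. Any claim that something is new, unique, unknown or untested is made for them only; others in the source may bear on it.

In an ADME assay on HEK293 cells (Homo sapiens) for cytotoxicity, read by resazurin assay, with a stated time of 48 h (on this read-out lower numbers stand for higher toxicity in this test and higher numbers for lower toxicity in this test), three compounds with a shared core have been measured in HEK293 cells. Compound 1 `O=S(=O)(Nc1ccc(-c2nc3ccccc3o2)cc1)c1ccc(Cl)c(C(F)(F)F)c1` gives 69000 nM, and compound 3 `O=S(=O)(Nc1ccc2oc(-c3ccccc3)nc2c1)c1ccc(Cl)c(C(F)(F)F)c1` gives 66000 nM, two values within the usual scatter of each other. Compound 2 `O=S(=O)(Nc1ccc(-c2nc3ccccc3o2)cc1)c1ccccc1Cl` stands at > 100000 nM, which is a limit of the assay and not a number. Its exact place is therefore unknown.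

The next compound to be tested is compound 4 `O=S(=O)(Nc1ccc(-c2nc3ccccc3o2)cc1)c1ccccc1O`, which is compound 2 with one change, from 2-chlorophenyl to 2-hydroxyphenyl: hydroxy in place of chloro on an aromatic carbon. This is hydroxy in place of chloro on an aromatic carbon, ortho to a large group. Going by the values given here, no measured pair in this small set shows what such a change does, so the expectation remains broad. The expected change is an at least 1.1-fold lower number from compound 2 to compound 4 (0.07 log units; that floor lies within the scatter), a small step that is not expected to go beyond the scatter, with a slight lean towards higher toxicity. That lean is only a cautious allowance, since compound 2 offers a limit as its starting point. The lower end of the expected range stays close to compound 1 at 69000 nM. For compound 4 the estimated value in this assay is 85000 nM, with an expected range from 40000 nM to 150000 nM.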

Compound 4, half-maximal cytotoxic concentration: > 100000 nM
Compound 4: no number, only a limit (the forecaster's own chance of this, stated with the estimate: 55%); at least 1.1-fold (0.07 log units) between middle value and limit.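

In this assay, compound 2 and compound 4 each give only a limit of the assay and not a number, so no step between them can be read: the limit of > 100000 nM in this assay, at which 2 of the 4 values shown sit.

The compounds shown leave open how far, if at all, hydroxy in place of chloro on an aromatic carbon shifts the half-maximal cytotoxic concentration.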